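A Trifluoromethyl Added to the Urea Phenyl

The source may hold more compounds than are shown below. What is called first, only, known or untested is meant among the compounds shown, and "the series" means these compounds.

compound 1, `COc1ccc(NC(=O)Nc2cccc(CNc3ncnc4ccccc34)c2)cc1`: 27300 nM
compound 2, `COc1cc2ncnc(NCc3cccc(NC(=O)Nc4ccccc4)c3)c2cc1OC`: 10000 nM

In a functional assay on MGC-803 cells (Homo sapiens) for antiproliferative activity, read by MTT assay (on this read-out higher numbers stand for weaker inhibition and lower numbers for stronger inhibition), compound 2 gives the lowest of the two numbers, and the gap to compound 1 lies beyond the scatter. Compound 3, `COc1cc2ncnc(NCc3cccc(NC(=O)Nc4cccc(C(F)(F)F)c4)c3)c2cc1OC`, differs from compound 2 by trifluoromethyl in place of hydrogen on an aromatic carbon. Among the compounds with values here, no measured pair shows this change, so nothing here fixes its size. The step is expected to be modest and toward stronger inhibition, as a 2.5-fold lower number from compound 2 to compound 3 (0.40 log units; beyond the scatter), yet the uncertainty is wide. Compound 3 is therefore estimated at 4000 nM, with a range from 800 nM to 15000 nM.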

Compound 3, half-maximal inhibitory concentration: > 50000 nM
Compound 3 ended at the assay's limit (the forecaster's own chance of this, stated with the estimate: 5%); middle value at least 12-fold (1.09 log units) from the limit.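

In this assay, within the data shown here, the urea phenyl of compound 2 proves sensitive at this position: trifluoromethyl in place of hydrogen gives an at least 5.0-fold higher number from compound 2 to compound 3 (0.69 log units; beyond the scatter), the first single-place step, and it runs toward weaker inhibition. Compound 3 gives > 50000 nM, which is a limit of the assay and not a number, so the step has a floor but no fixed size: the limit of > 50000 nM in this assay, at which 1 of the 3 values shown sits.

Going by these compounds, only hydrogen and trifluoromethyl are compared at this carbon, so it remains open whether a chlorine atom, a methyl or an amine there would be tolerated. On these data alone, it also remains open whether trifluoromethyl would behave the same way on another carbon of this ring.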